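The compounds below may be only part of what the source reports. "The series", "measured", "known", "first", "only" and "open" are said of these compounds alone.

Measured compounds in a functional assay on A549 cells (Homo sapiens) for cytotoxicity, read by WST assay, with a stated time of 72 h; a higher number here means a weaker inhibitor, a lower number a stronger inhibitor:

Compound 1, `COc1cc2c(Nc3nc4ccc(C(=O)Nc5c(C)cccc5Cl)cc4s3)ncnc2cc1OCCCN1CCCCC1C`: 6700 nM
Compound 2, `COc1cc2c(Nc3nc4ccc(C(=O)Nc5c(C)cc(C)cc5C)cc4s3)ncnc2cc1OCCCN1CCCCC1C`: 5800 nM
Compound 3, `CCN(CC)CCCOc1cc2ncnc(Nc3nc4ccc(C(=O)Nc5c(C)cccc5Cl)cc4s3)c2cc1OC`: 10600 nM

All three values of this assay lie within the scatter of one another, so no ordering among them is claimed.

The change from compound 1 to compound 2 is the following: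

2,4,6-trimethylphenyl in place of 2-chloro-6-methylphenyl on an amide-type nitrogen

In this assay it gave a 1.2-fold lower number from compound 1 to compound 2 (0.06 log units; within the scatter).

Compound 4, `CCN(CC)CCCOc1cc2ncnc(Nc3nc4ccc(C(=O)Nc5c(C)cc(C)cc5C)cc4s3)c2cc1OC`, is not yet measured. Its core is that of compound 3, which differs from the core of compound 1 as follows:

diethylamino in place of 2-methylpiperidin-1-yl on a saturated chain carbon, three bonds along the chain from an oxygen on an aromatic ring

That core change, on its own, gave a 1.6-fold higher number from compound 1 to compound 3 (0.20 log units; within the scatter).

The change from compound 3 to compound 4 is:

2,4,6-trimethylphenyl in place of 2-chloro-6-methylphenyl on an amide-type nitrogen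

The place of this change is described in the same words as for the change from compound 1 to compound 2, so it is the same change, made on a core that differs only in the amine on the chain. Going by the values given here, the one measured instance of this change is within the scatter, and the core difference is also within the scatter, so there is no indication that the amine alters how the aryl change reads out.

For compound 4 the expected step is therefore a 1.2-fold lower number from compound 3 to compound 4 (0.07 log units; within the scatter), beside a 1.2-fold lower number from compound 1 to compound 2 (0.06 log units; within the scatter), resting on the value of compound 3, 10600 nM, and on the step from compound 1 to compound 2.

The estimate for compound 4 in this assay is 9000 nM, expected to fall between 4500 nM and 18000 nM.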

Compound 4, half-maximal inhibitory concentration: 5700 nM
Estimate against measurement, compound 4: 1.6-fold (0.20 log units) above; measured number inside the range.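

In this assay, 2,4,6-trimethylphenyl in place of 2-chloro-6-methylphenyl on the amide-type nitrogen, now read on the core carrying diethylamino, gives a 1.9-fold lower number from compound 3 to compound 4 (0.27 log units; within the scatter), and this reading does not differ from the earlier one on the core carrying 2-methylpiperidin-1-yl: the same change on two cores in this assay, a 1.2-fold lower number (0.06 log units; within the scatter) from compound 1 to compound 2 and a 1.9-fold lower number (0.27 log units; within the scatter) from compound 3 to compound 4, 1.6-fold (0.21 log units) apart, within the scatter of two such steps

The amine change, read on the cores carrying 2,4,6-trimethylphenyl, gives a 1.0-fold lower number from compound 2 to compound 4 (0.01 log units; within the scatter), and it also agrees with its earlier reading: the same change on two cores in this assay, a 1.6-fold higher number (0.20 log units; within the scatter) from compound 1 to compound 3 and a 1.0-fold lower number (0.01 log units; within the scatter) from compound 2 to compound 4, 1.6-fold (0.21 log units) apart, within the scatter of two such steps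

Each change therefore carries between these two cores without a detectable difference, but every step here lies within the scatter, so the result shows neither that either change has a real effect of its own in this assay nor that the two changes act independently, and two pairs cannot establish transfer to other cores.

It remains open whether a group that departs further from those shown, such as morpholin-4-yl in place of diethylamino, a longer chain, or 2,6-dichlorophenyl on the amide-type nitrogen, would give a step beyond the scatter in this assay. A step of that size would give a firmer test of whether a change carries from one core to another in this series.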